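The source may report more compounds than this note shows. Statements on the series, on what has been measured and on what is new or still open speak of the compounds shown alone.

Measured compounds in a functional assay on MCF7 cells (Homo sapiens) for cytotoxicity, read by XTT assay, with a stated time of 24 h; on this read-out lower numbers stand for stronger inhibition and higher numbers for weaker inhibition:
- compound 1 `Cc1cc(Cl)c2c(c1O)C(=O)C=CC2=O` gives 10000 nM
- compound 2 `COc1c(C)cc(Cl)c2c1C(=O)C=CC2=O` gives 16200 nM
- compound 3 `CC(=O)Oc1cc(OC(C)=O)c2c(OC(C)=O)c(C)cc(Cl)c2c1OC(C)=O` gives 57500 nM

Compound 2 stands level with compound 1 within the scatter, and compound 3 gives a higher number than compound 2, beyond the scatter. Next is compound 4 `CC(=O)Oc1c(C)cc(Cl)c2c1C(=O)C=CC2=O`, with acetyl in place of methyl on an oxygen on an aromatic ring. Among the compounds with values here, the only measured step at this oxygen, a 1.6-fold higher number from compound 1 to compound 2 (0.21 log units; within the scatter), stays within the scatter. Within the data shown here, compound 3 carries acetoxy groups but differs from compound 2 in more than one place, so it offers no direct step. No change beyond the scatter is therefore expected in this assay, with the estimated step being a 1.2-fold lower number from compound 2 to compound 4 (0.10 log units; within the scatter). For compound 4 the expected value is 13000 nM, with an estimated range of 6000 nM to 30000 nM.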

Compound 4, half-maximal inhibitory concentration: 18700 nM
Estimate against measurement, compound 4: 1.4-fold (0.16 log units) below, and the stated range covers the measured number.
By their numbers in this assay, from the lowest: compounds 1, 2 and 4 (each within the scatter of the next); then compound 3.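

In this assay, acetyl on this oxygen on an aromatic ring gives (a 1.2-fold higher number from compound 2 to compound 4 (0.06 log units; within the scatter)), and acetyl in place of hydrogen gives (a 1.9-fold higher number from compound 1 to compound 4 (0.27 log units; within the scatter)). Hydrogen, methyl and acetyl at this oxygen therefore stand level within the scatter, so the acetyl group, with its added carbonyl, separates compound 4 from neither compound 1 nor compound 2. No available evidence bears on this result. Still open, going by these compounds, is whether a longer acyl chain, or an acyl group carrying an amine or a carboxylic acid, would move the number beyond the scatter at this oxygen.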